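Vinyl-thiazole replaces isopropyl-oxazole on the shared core

A few compounds are considered here, and "the series" means these few. Any claim that something is new, unique, unknown or untested is made for them only; others in the source may bear on it.

Three compounds share one core and differ in the groups on its fused ring. Compound 1 `COc1ccc2c(O[C@H]3C[C@H]4C(=O)N(C)CCCC/C=C/[C@@H]5C[C@@]5(C(=O)NS(=O)(=O)C5(C)CC5)NC(=O)N4C3)cc(-c3nc(C(F)(F)F)cs3)nc2c1C` gives 75000 nM in an ADME assay on Huh-7 cells (Homo sapiens) for cytotoxicity, read by colorimetric assay; a higher number here means that more compound is tolerated, a lower number that less compound is tolerated. Compound 2 `COc1ccc2c(O[C@H]3C[C@H]4C(=O)N(C)CCCC/C=C/[C@@H]5C[C@@]5(C(=O)NS(=O)(=O)C5(C)CC5)NC(=O)N4C3)cc(-c3nc(C(C)C)cs3)nc2c1Br` gives 51200 nM in this assay, and compound 3 `COc1ccc2c(O[C@H]3C[C@H]4C(=O)N(C)CCCC/C=C/[C@@H]5C[C@@]5(C(=O)NS(=O)(=O)C5(C)CC5)NC(=O)N4C3)cc(-c3cc(C(C)C)on3)nc2c1Cl` gives 75000 nM in this assay. Compound 3 thus stands level with compound 1 at the digits shown, the two together the highest of the three numbers, and its gap to compound 2 lies within the usual scatter. Compound 4 `C=Cc1csc(-c2cc(O[C@H]3C[C@H]4C(=O)N(C)CCCC/C=C/[C@@H]5C[C@@]5(C(=O)NS(=O)(=O)C5(C)CC5)NC(=O)N4C3)c3ccc(OC)c(Cl)c3n2)n1` differs from compound 3 by 4-vinyl-1,3-thiazol-2-yl in place of 5-isopropyl-1,2-oxazol-3-yl on an aromatic carbon. Among the measured compounds shown here, no step between measured compounds covers this change, and all three measured values lie close together. The expected step in this assay is a 1.2-fold lower number from compound 3 to compound 4 (0.06 log units; within the scatter), none beyond the scatter. Compound 4 is estimated at 65000 nM, within 35000 nM to 100000 nM.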

Compound 4, half-maximal cytotoxic concentration: 57100 nM
Estimate against measurement, compound 4: 1.1-fold (0.06 log units) above, within the range that was stated.
By their numbers in this assay, from the lowest: compounds 2, 4, 1 and 3 (each within the scatter of the next).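

In this assay, 4-vinyl-1,3-thiazol-2-yl in place of 5-isopropyl-1,2-oxazol-3-yl on this aromatic carbon gives a 1.3-fold lower number from compound 3 to compound 4 (0.12 log units; within the scatter). Among the compounds shown here, this is the first single-place step available here, and it shows that exchanging one five-membered aromatic ring for the other leaves the reading within the scatter. No measurement at hand bears on the reason for this result.

The compounds shown leave open how an amine or a carboxylic acid on this aromatic carbon would read in this assay. They also do not separate the contribution of the vinyl group from that of the ring carrying it.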